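This account rests on a few compounds, and the source may have more. Where it says the series, first, only, none or still open, it means among the compounds named here.

Two aryl amides share one core. Compound 1 `COc1cc(NC(=O)c2ccc(C)c(C#Cc3cc(-c4cnn(C)c4)cnc3N)c2)cc(OC)c1` gives 397 nM in an ADME assay on RBL-2H3 cells (Rattus norvegicus) for cytotoxicity, read by CCK-8 assay, with a stated time of 24 h; a higher number here means that more compound is tolerated, a lower number that less compound is tolerated; compound 2 `Cc1ccc(C(=O)Nc2cccc(C(F)(F)F)c2)cc1C#Cc1cc(-c2cnn(C)c2)cnc1N` gives 7 nM, the lowest of the two numbers, and the step of a 57-fold lower number from compound 1 to compound 2 (1.75 log units; beyond the scatter) separates them. Compound 3 `Cc1ccc(C(=O)Nc2cccc(OC(F)(F)F)c2)cc1C#Cc1cc(-c2cnn(C)c2)cnc1N` carries trifluoromethoxy in place of trifluoromethyl on an aromatic carbon. Going by the values given here, no measured step runs along this change; the only step known, from compound 1 to compound 2, swaps the whole substituted phenyl and therefore bears on it only loosely. For compound 3 no step beyond the scatter is expected in this assay, a 1.4-fold higher number from compound 2 to compound 3 (0.15 log units; within the scatter), and its estimate is 10 nM, expected within 3 nM to 40 nM.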

Compound 3, half-maximal cytotoxic concentration: 33.7 nM
The estimate for compound 3 lay 3.4-fold (0.53 log units) below the measured number, within the range that was stated.
By their numbers in this assay, from the lowest: compound 2; then compound 3; then compound 1.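

In this assay, trifluoromethoxy in place of trifluoromethyl on an aromatic carbon gives a 4.8-fold higher number from compound 2 to compound 3 (0.68 log units; beyond the scatter) and so counts as a real change at this position, not as an exchange of equivalent groups. The swap of 3,5-dimethoxyphenyl for 3-(trifluoromethoxy)phenyl gives a 12-fold lower number from compound 1 to compound 3 (1.07 log units; beyond the scatter) in the same direction as the swap to 3-(trifluoromethyl)phenyl. Nothing available accounts for the gap between the two fluorinated groups. Open, going by these compounds, is how this assay would respond to an amine or a carboxylic acid at this position, and whether a longer fluorinated chain would follow trifluoromethoxy or trifluoromethyl.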